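A Methyl Traded for an Amide on a Shared Core

A few compounds are considered here, and "the series" means these few. Any claim that something is new, unique, unknown or untested is made for them only; others in the source may bear on it.

Compound 1 `Cc1cccc(C)c1Nc1nc2c(Nc3ccc(C(F)(F)F)cc3)ncnc2s1` gives 23 nM in a functional assay on HEK293 cells for antagonist activity at transient receptor potential cation channel subfamily V member 1 (Homo sapiens), read by calcium flux; a higher number here means a weaker inhibitor, a lower number a stronger inhibitor.
Compound 2 `N#Cc1cc(Cl)c(Nc2nc3c(Nc4ccc(C(F)(F)F)cc4)ncnc3s2)c(Cl)c1` gives 95 nM in this assay.
Compound 3 `Cc1ccc(Nc2ncnc3sc(Nc4c(Cl)cccc4Cl)nc23)cc1` gives 33 nM in this assay.

Among these three numbers compound 3 stands second highest: its value and that of compound 1 lie within the usual scatter of each other, while compound 2 sits higher, beyond the scatter. Compound 4 `O=C(c1ccc(Nc2ncnc3sc(Nc4c(Cl)cccc4Cl)nc23)cc1)N1CCCC1` differs from compound 3 in one place only: (pyrrolidin-1-yl)carbonyl in place of methyl on an aromatic carbon.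

Among the measured compounds shown here, only one step between measured compounds is on record, a 4.1-fold higher number from compound 1 to compound 2 (0.62 log units; beyond the scatter), and it alters the other nitrogen-linked aryl group on the shared core, not the ring that changes here. For the measured compounds named here, no measured step tests a substituent at the place that changes from compound 3 to compound 4, so the data give no direct guide for its direction or size. A step of modest size is therefore expected in this assay, as a 1.8-fold higher number from compound 3 to compound 4 (0.26 log units; within the scatter), with a wide range allowed. Compound 4 is estimated at 60 nM, between 15 nM and 250 nM.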

Compound 4, half-maximal inhibitory concentration: > 5000 nM
Compound 4 gave a limit, no number (the forecaster's own chance of this, stated with the estimate: 5%); middle value at least 83-fold (1.92 log units) from the limit.
By their numbers in this assay, from the lowest: compounds 1 and 3 (each within the scatter of the next); then compound 2. At a limit, above all of these: compound 4.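

In this assay, among the compounds shown here, the place on the aromatic ring that holds methyl in compound 3 proves far less tolerant than the earlier compounds could show: putting (pyrrolidin-1-yl)carbonyl there gives an at least 150-fold higher number from compound 3 to compound 4 (2.18 log units; beyond the scatter). This step is much larger than the only earlier one, a 4.1-fold higher number from compound 1 to compound 2 (0.62 log units; beyond the scatter), which changed the other nitrogen-linked aryl group and left the compound in the same broad range of values. Compound 4 gives a limit and not a number, so the true size of the loss stays unknown and the step gives only its smallest size: the limit of > 5000 nM in this assay, at which 1 of the 4 values shown sits.

The change brings in a carbonyl and a five-membered ring together, so the compounds shown cannot tell which part accounts for the loss. From the compounds shown here alone, how an ethyl chain, a methoxy group or an unsubstituted amide would fare at this place remains open.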